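Adding a Methoxy Group: Compound 2 to Compound 4

The source may report more compounds than this note shows. Statements on the series, on what has been measured and on what is new or still open speak of the compounds shown alone.

Three compounds sharing one core were tested in a functional assay on the whole organism (strain albino) with Rattus norvegicus as the target, in the maximal electroshock model, with a stated time of 1 h, at a dose of 30 mg/kg by the intraperitoneal route; on this read-out higher numbers stand for more inhibition at the one dose given (going by the name of the read-out) and lower numbers for less inhibition. Compound 1 `COc1ccc(/C=N/c2nnc(CNn3c(C)nc4ccccc4c3=O)s2)cc1` gives 50%. Compound 2 `Cc1nc2ccccc2c(=O)n1NCc1nnc(/N=C/c2ccc(O)cc2)s1` gives 50%, and compound 3 `Cc1nc2ccc(Br)cc2c(=O)n1NCc1nnc(/N=C/c2ccc(O)cc2)s1` gives 50%. The step of no change at the digits printed from compound 1 to compound 2 (within the scatter) was hydrogen in place of methyl on an oxygen on an aromatic ring; the step of no change at the digits printed from compound 2 to compound 3 (within the scatter) was bromo in place of hydrogen on an aromatic carbon. Compound 2 therefore stands level with compounds 1 and 3, and no difference among the three rises above the scatter.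

Compound 4 `COc1cc(/C=N/c2nnc(CNn3c(C)nc4ccccc4c3=O)s2)ccc1O` differs from compound 2 in one place: methoxy in place of hydrogen on an aromatic carbon. The change turns the 4-hydroxyphenyl group into a 4-hydroxy-3-methoxyphenyl group, the new methoxy ortho to the hydroxy group. The step from compound 1 to compound 2 bears most directly on this; it also altered what sits on the oxygen of that aromatic ring, and it produced no shift beyond the scatter. The step from compound 2 to compound 3 was equally flat. The expected step of no change at the digits printed from compound 2 to compound 4 (within the scatter) is thus none beyond the scatter. Compound 4 is estimated at 50%, within a range from 35% to 65%.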

Compound 4, a percentage reported as inhibition, in the whole organism at one dose (the size of the read-out at that dose, not a potency): 50%
Estimate against measurement, compound 4: no gap at the digits printed, and the stated range covers the measured number.
By their numbers in this assay, from the lowest: compounds 1, 2, 3 and 4 (each within the scatter of the next).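

Compounds 1, 2 and 3 all carry hydrogen on the aromatic carbon ortho to a hydroxy group (or, in compound 1, ortho to the methoxy-bearing carbon's oxygen position is left unchanged), so only compound 4 tests a substituent there. In this assay, placing a methoxy group on that carbon gives the step of no change at the digits printed from compound 2 to compound 4 (within the scatter), so this position accepts a group of 2 heavy atoms without a shift in this read-out. Exchanging the whole aryl group leaves the picture unchanged, with the step of no change at the digits printed from compound 1 to compound 4 (within the scatter), and nothing measured here offers an explanation for these flat results.

From the compounds shown here alone, what remains open is whether a larger or differently built group on this carbon, such as a butoxy chain, an amine or a carboxylic acid, would move the read-out. A single dose also leaves open whether these compounds would separate at other doses.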